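This account rests on a few compounds, and the source may have more. Where it says the series, first, only, none or still open, it means among the compounds named here.

Measured so far in a functional assay on PC-3 cells (Homo sapiens) for cytotoxicity, read by MTT assay, with a stated time of 48 h; a higher number here means a weaker inhibitor, a lower number a stronger inhibitor:

compound 1 `O=C(c1ccccc1)N1N=C(c2cc3ccccc3oc2=O)CC1c1ccccc1` gives 5870 nM
compound 2 `O=C(CN1CCCC1)N1N=C(c2cc3ccccc3oc2=O)CC1c1ccccc1` gives 50200 nM
compound 3 `CC1CCCCN1CC(=O)N1N=C(c2cc3ccccc3oc2=O)CC1c1ccccc1` gives 36300 nM

Among these three, compound 3 sits second highest: it lies close to compound 2, the two being within the usual scatter, and well apart from compound 1, which gives the lowest number of the set.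

Compound 4 `CCN(CC)C1CCN(CC(=O)N2N=C(c3cc4ccccc4oc3=O)CC2c2ccccc2)CC1` differs from compound 3 in a single place: 4-(diethylamino)piperidin-1-yl in place of 2-methylpiperidin-1-yl on a saturated chain carbon bound to a carbonyl carbon. Both groups are cyclic amines attached through a one-carbon link to the carbonyl, so the shared core and the way the amine is joined stay the same.

Two comparisons bear on this change. Replacing the phenyl on the carbonyl by an amine-bearing chain gave an 8.6-fold higher number from compound 1 to compound 2 (0.93 log units; beyond the scatter) and a 6.2-fold higher number from compound 1 to compound 3 (0.79 log units; beyond the scatter), so the cyclic amines as a class sit well away from compound 1. Exchanging one cyclic amine for another, however, gave only a 1.4-fold lower number from compound 2 to compound 3 (0.14 log units; within the scatter), within the scatter. Since the step to compound 4 is again an exchange of one cyclic amine for another, no change beyond the scatter in this assay is expected, and the estimated step is a 1.0-fold lower number from compound 3 to compound 4 (0.02 log units; within the scatter). Compound 4 is therefore estimated at 35000 nM, with a range from 12000 nM to 100000 nM.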

Compound 4, half-maximal inhibitory concentration: 26100 nM
Compound 4: the middle estimate sits 1.3-fold (0.13 log units) above what was measured; the measured number falls inside the stated range.
By their numbers in this assay, from the lowest: compound 1; then compounds 4, 3 and 2 (each within the scatter of the next).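

In this assay, 4-(diethylamino)piperidin-1-yl on a saturated chain carbon bound to a carbonyl carbon stands level with the other two cyclic amines: replacing 2-methylpiperidin-1-yl gives a 1.4-fold lower number from compound 3 to compound 4 (0.14 log units; within the scatter), and replacing pyrrolidin-1-yl gives a 1.9-fold lower number from compound 2 to compound 4 (0.28 log units; within the scatter). The three cyclic amines cannot be told apart here, even with a diethylamino group added to the ring, yet the distance from the phenyl compound persists, at a 4.4-fold higher number from compound 1 to compound 4 (0.65 log units; beyond the scatter). No evidence is at hand to explain this pattern.

Going by these compounds, it remains open whether a morpholine ring or an open-chain amine such as diethylamino on the same carbon would stay level with these three. A longer chain carrying the amine, or a carboxylic acid in its place, is equally untested among the compounds shown.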